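The source may report more compounds than this note shows. Statements on the series, on what has been measured and on what is new or still open speak of the compounds shown alone.

Measured so far in a functional assay (aorta) for antagonist activity, with Oryctolagus cuniculus as the target; on this read-out lower numbers stand for stronger inhibition and higher numbers for weaker inhibition:

- compound 1 `CCCCc1ccc(CNC(=O)Nc2ccccc2)c(=O)n1Cc1ccc(-c2ccccc2-c2nn[nH]n2)cc1`: 30 nM
- compound 2 `CCCCc1ccc(CNC(=O)NC2CCCCC2)c(=O)n1Cc1ccc(-c2ccccc2-c2nn[nH]n2)cc1`: 90 nM
- compound 3 `CCCCc1ccc(CN(Cc2ccccc2)C(C)=O)c(=O)n1Cc1ccc(-c2ccccc2-c2nn[nH]n2)cc1`: 1 nM

Compound 3 gives the lowest number of the three, and its steps to both others lie beyond the scatter: a 30-fold lower number from compound 1 to compound 3 (1.48 log units; beyond the scatter) and a 90-fold lower number from compound 2 to compound 3 (1.95 log units; beyond the scatter). Within this small set compound 3 is therefore the most potent. Within the data shown here, the only other step, a 3.0-fold higher number from compound 1 to compound 2 (0.48 log units; beyond the scatter), is modest.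

Compound 4 `CCCCc1ccc(CN(C)S(=O)(=O)c2ccc(C)cc2)c(=O)n1Cc1ccc(-c2ccccc2-c2nn[nH]n2)cc1` keeps the shared core of compound 3 and changes only the group on the saturated chain carbon bound to an aromatic carbon: methyl((4-methylphenyl)sulfonyl)amino in place of acetyl(benzyl)amino on a saturated chain carbon bound to an aromatic carbon. Both large steps recorded so far, from compound 1 and from compound 2 to compound 3, concern exactly this position, so this assay responds strongly to what stands there. Neither of them tests a sulfonyl group, and the record holds no sulfonamide at all, so the direction of the new step is not anchored by any measured pair.

Compound 4 is therefore expected to remain in the range of the two acylated compounds rather than return to the urea numbers, with an estimate of 5 nM in this assay, between 1 nM and 30 nM, which corresponds to an expected step of a 5.0-fold higher number from compound 3 to compound 4 (0.70 log units; beyond the scatter).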

Compound 4, half-maximal inhibitory concentration: 8 nM
Beside the measured number, compound 4's estimate is 1.6-fold (0.20 log units) below it; low and high end bracket the measured number.
By their numbers in this assay, from the lowest: compound 3; then compound 4; then compound 1; then compound 2.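

In this assay, among these compounds, the first sulfonyl group at this position keeps the number clearly under both ureas (a 3.8-fold lower number from compound 1 to compound 4 (0.57 log units; beyond the scatter); an 11-fold lower number from compound 2 to compound 4 (1.05 log units; beyond the scatter)), so a low number on the saturated chain carbon bound to an aromatic carbon is no longer tied to acetyl(benzyl)amino alone. The methyl((4-methylphenyl)sulfonyl)amino group still falls short of that group (an 8.0-fold higher number from compound 3 to compound 4 (0.90 log units; beyond the scatter)), which shows that this position also separates the two non-urea groups, and not only these from the ureas. No measurement shown here explains this order of the groups.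

The step from compound 3 to compound 4 swaps the carbonyl for a sulfonyl, the benzyl for a methyl and the position of the aromatic ring all at once, so the compounds shown cannot assign it to any one of these parts. Open as well are a benzyl in place of the methyl on the sulfonamide nitrogen, a plain methanesulfonyl group in place of the 4-methylphenylsulfonyl group, and a free amine or a carboxylic acid on this same carbon.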